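The compounds below may be only part of what the source reports. "The series", "measured", "known", "first", "only" and "open" are said of these compounds alone.

Two members of the series have been run in a functional assay on MCF7 cells (Homo sapiens) for antiproliferative activity, read by MTT assay, with a stated time of 72 h (a lower number here means a stronger inhibitor, a higher number a weaker inhibitor), so far. Compound 1 `Cc1cc(Cl)ccc1NCC(=O)N[C@H]1CCOC1=O` reaches only the limit of the assay, > 64000 nM. Compound 2 `O=C(CNc1ccc(Cl)cc1Cl)N[C@H]1CCOC1=O` likewise stops at a limit, > 64000 nM. The single measured step, a step that the two limits leave unreadable from compound 1 to compound 2, is therefore not readable; on the numbers shown compound 2 stands at a limit and nowhere else, which is what the limit of > 64000 nM in this assay, at which 2 of the 2 values shown sit, records. Compound 3 `O=C(CNc1ccccc1Cl)N[C@H]1CCOC1=O` differs from compound 2 by hydrogen in place of chloro on an aromatic carbon. For the measured compounds named here, no measured step bears on this change in a readable way: the only step between measured compounds is itself hidden behind the two limits. The expectation for compound 3 in this assay is that the step that the limit leaves unreadable from compound 2 to compound 3 stays within the scatter. Compound 3 is thus estimated at 80000 nM, within 20000 nM to 300000 nM, and most likely again reported only as a limit.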

Compound 3, half-maximal inhibitory concentration: > 64000 nM
Compound 3 gave a limit, no number; the forecaster's own chance of this, stated with the estimate: 85%; the middle value is on the limit's open side.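

In this assay compound 3 gives > 64000 nM, a limit of the assay and not a number, so no new step can be read between compound 2 and compound 3. The compounds shown leave open whether any member of this series gives a measurable value in this assay.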